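The source may hold more compounds than are shown below. What is called first, only, known or untested is meant among the compounds shown, and "the series" means these compounds.

Working notes on the series. Compound 1 `CC(C)[C@@H]1CC[C@@H](C)C[C@@]12N(C)C(=O)[C@@H]1[C@H]3C(=O)N(c4ccccc4)C(=O)[C@H]3ON12` is the parent of the set. In a functional assay, read by spectrophotometry, with a stated time of 2 h, tested at 2 mg/mL (on this read-out lower numbers stand for a weaker effect and higher numbers for a stronger effect at the one concentration tested), compound 1 gives 48.2%. Compound 2 `COc1ccc(N2C(=O)[C@H]3[C@H](ON4[C@@H]3C(=O)N(C)[C@@]43C[C@H](C)CC[C@H]3C(C)C)C2=O)cc1` gives 55.7% in this assay, and compound 3 `Cc1ccc(N2C(=O)[C@H]3[C@H](ON4[C@@H]3C(=O)N(C)[C@@]43C[C@H](C)CC[C@H]3C(C)C)C2=O)c(C)c1` gives 57%. Compound 1 thus carries the smallest of the three numbers shown, but the distances to the other two are small: a number 7.5 percentage points higher from compound 1 to compound 2 (within the scatter) and a number 8.8 percentage points higher from compound 1 to compound 3 (within the scatter), both within the scatter, so the three compounds cannot be told apart on this read-out. The step of a number 1.3 percentage points higher from compound 2 to compound 3 (within the scatter) is likewise within the scatter.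

Compound 4 `CC(C)[C@@H]1CC[C@@H](C)C[C@@]12N(C)C(=O)[C@@H]1[C@H]3C(=O)N(c4ccc5ccccc5c4)C(=O)[C@H]3ON12` is not yet measured. It differs from compound 1 as follows: naphthalen-2-yl in place of phenyl on an amide-type nitrogen in a ring. The two measured steps that bear on this are those in which the aryl group on the amide-type nitrogen was varied from compound 1, namely a number 7.5 percentage points higher from compound 1 to compound 2 (within the scatter) and a number 8.8 percentage points higher from compound 1 to compound 3 (within the scatter); neither moved the number beyond the scatter. On that basis no step beyond the scatter is expected for compound 4 in this assay, with at most a slight upward lean, that is a number 4.8 percentage points higher from compound 1 to compound 4 (within the scatter). For compound 4 in this assay the expected number is therefore 53%, estimated to lie between 40% and 66%.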

Compound 4, a percentage reported as activity, at one concentration (the size of the read-out at that concentration, not a potency): 36.5%
The estimate for compound 4 lay 16.5 percentage points above the measured number, and the stated range ends above it.
By their numbers in this assay, from the lowest: compound 4; then compounds 1, 2 and 3 (each within the scatter of the next).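

At the amide-type nitrogen, the aryl group can shift the number in this assay beyond the scatter: replacing phenyl with naphthalen-2-yl gives a number 11.7 percentage points lower from compound 1 to compound 4 (beyond the scatter) and the same group gives a number 19.2 percentage points lower from compound 2 to compound 4 (beyond the scatter) and a number 20.5 percentage points lower from compound 3 to compound 4 (beyond the scatter) when it replaces the other two aryl groups. Phenyl, 4-methoxyphenyl and 2,4-dimethylphenyl stay within the scatter of one another, so this position is not indifferent to every aryl change, and the lower number appears here with two six-membered aromatic rings of carbon only in place of one, with hydrogen-bond donors, hydrogen-bond acceptors and net charge unchanged at zero. No available measurement explains the lower number.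

Within the data shown here, with only one compound carrying two aromatic rings at this position, it remains open whether the lower number is specific to naphthalen-2-yl or extends to groups such as naphthalen-1-yl, biphenyl-4-yl or benzyl. Also open, on these data alone, is how this position responds to a pyridine ring, or to an amine or a carboxylic acid on the phenyl ring, and whether the step holds at concentrations other than the one tested.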